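One Methoxy Fewer on the Compound 2 Aryl Group

The compounds below may be only part of what the source reports. "The series", "measured", "known", "first", "only" and "open" are said of these compounds alone.

In a functional assay on HCT-116 cells (Homo sapiens) for antiproliferative activity, read by sulforhodamine B assay, with a stated time of 48 h (a lower number here means a stronger inhibitor, a higher number a weaker inhibitor), compound 1 (`COc1cc(OC)c(C(=O)/C=C/c2ccc(OC)c(OC)c2)c(OCC=C(C)C)c1`) gives 5700 nM and compound 2 (`COc1cc(OCC=C(C)C)c(C(=O)/C=C/c2cc(OC)c(OC)c(OC)c2)c(OC)c1CC=C(C)C`) gives 4200 nM with the two numbers within the scatter of each other. Compound 3 (`COc1ccc(/C=C/C(=O)c2c(OCC=C(C)C)cc(OC)c(CC=C(C)C)c2OC)cc1OC`) differs from compound 2 by hydrogen in place of methoxy on an aromatic carbon so 3,4,5-trimethoxyphenyl becomes 3,4-dimethoxyphenyl. Compound 1 also carries 3,4-dimethoxyphenyl and gives 5700 nM so no step beyond the scatter is expected in this assay for this change. The estimated 1.2-fold higher number from compound 2 to compound 3 (0.08 log units; within the scatter) stays within that scatter. Compound 3 is expected at 5000 nM with an estimated range from 2000 nM to 12000 nM for repeated measurements.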

Compound 3, half-maximal inhibitory concentration: 7400 nM
Beside the measured number, compound 3's estimate is 1.5-fold (0.17 log units) below it, and the stated range covers the measured number.
By their numbers in this assay, from the lowest: compounds 2, 1 and 3 (each within the scatter of the next).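

Taking the methoxy off this aromatic carbon, so that 3,4,5-trimethoxyphenyl becomes 3,4-dimethoxyphenyl, gives a 1.8-fold higher number from compound 2 to compound 3 (0.25 log units; within the scatter) in this assay, so hydrogen and methoxy cannot be told apart here. With 3,4-dimethoxyphenyl on both compounds, 3-methylbut-2-en-1-yl in place of hydrogen on an aromatic carbon gives a 1.3-fold higher number from compound 1 to compound 3 (0.11 log units; within the scatter), which also cannot be told from the scatter. No measurement offered here gives a reason for either result. Going by these compounds, whether an amine or a carboxylic acid on this aromatic carbon would move the number beyond the scatter stays open.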